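Hydroxamic Replacement on the Cyclopropane Amide of Compound 3

This account rests on a few compounds, and the source may have more. Where it says the series, first, only, none or still open, it means among the compounds named here.

Compound 3 `Cc1nc(-c2ccc(C(F)(F)F)cc2)sc1CNc1ccc([C@H]2C[C@@H]2C(=O)N[C@H](C)c2ccccc2)cc1` stands lowest of the three maximal responses recorded in a functional assay on CHO cells for agonist activity at Free fatty acid receptor 1 (Homo sapiens), read by a luciferase reporter; on this read-out higher numbers stand for larger maximal responses and lower numbers for smaller maximal responses: compound 3 reaches 42%, whereas compound 1 `Cc1nc(-c2ccc(C(F)(F)F)cc2)sc1CNc1ccc(/C=C/C(=O)O)cc1` reaches 95% and compound 2 `Cc1nc(-c2ccc(C(F)(F)F)cc2)sc1CNc1ccc(C(C)CC(=O)O)cc1` reaches 109%. Among the measured compounds shown here, the single step recorded between measured compounds, a number 14 percentage points higher from compound 1 to compound 2 (beyond the scatter), concerns the 2-carboxyethenyl and 1-(carboxymethyl)ethyl groups and does not touch the amide-type nitrogen altered here. Compound 4 `Cc1nc(-c2ccc(C(F)(F)F)cc2)sc1CNc1ccc([C@H]2C[C@@H]2C(=O)NO)cc1` differs from compound 3 in that (hydroxy in place of 1-phenylethyl on an amide-type nitrogen). For the measured compounds named here, no measured step bears on this change; the hydroxycarbamoyl end of compound 4 is untested, and the two carboxylic compounds show only that this shared core can reach large responses. Compound 4 is therefore expected to rise moderately, a number 28 percentage points higher from compound 3 to compound 4 (beyond the scatter), with a wide range, giving an estimated 70% (from 40% to 105%).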

Compound 4, largest response reached (reported as percent of maximum), in percent of the reference or control that the assay uses: 78%
Compound 4: middle estimate off by 8 percentage points, on the low side, within the range that was stated.
By their numbers in this assay, from the lowest: compound 3; then compound 4; then compound 1; then compound 2.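

In this assay, hydroxy in place of 1-phenylethyl on the amide-type nitrogen gives a number 36 percentage points higher from compound 3 to compound 4 (beyond the scatter), which shows that the maximal response depends on the group at this nitrogen. The hydroxycarbamoyl end does not restore the level of the carboxylic compounds: 2-(hydroxycarbamoyl)cyclopropyl in place of the earlier side chains gives a number 31 percentage points lower from compound 2 to compound 4 (beyond the scatter) and a number 17 percentage points lower from compound 1 to compound 4 (beyond the scatter), each beyond the scatter. Nothing available accounts for these differences.

The compounds shown leave open how a methoxy group or a plain hydrogen on this nitrogen would compare with hydroxy. They also leave open whether a carboxylic acid on the cyclopropyl ring would match hydroxycarbamoyl.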